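The compounds below may be only part of what the source reports. "The series", "measured", "known", "first", "only" and "open" are said of these compounds alone.

Compound 1 `CCn1c(C(=O)NCCCN(C)C)ccc1C(CC)(CC)c1ccc(OCC(=O)C(C)(C)C)c(C)c1` gives 96 nM in an assay on HL-60 cells for agonist activity at vitamin D3 receptor (Homo sapiens), read by microscopy, with a stated time of 96 h; on this read-out lower numbers stand for an effect already at smaller amounts and higher numbers for an effect only at larger amounts of compound. Compound 2 `CCn1c(C(=O)N(C)CCC#N)ccc1C(CC)(CC)c1ccc(OCC(=O)C(C)(C)C)c(C)c1` gives 9800 nM in this assay. Compound 3 `CCn1c(C(=O)NCCCN(C)C)ccc1C(CC)(CC)c1ccc(OCC(O)C(C)(C)C)c(C)c1` gives 37 nM in this assay, the lowest of the three numbers, with compound 1 nearest and compound 2 furthest. Compound 4 `CCn1c(C(=O)N(C)c2ccccc2)ccc1C(CC)(CC)c1ccc(OCC(O)C(C)(C)C)c(C)c1` has not been measured in this assay. It differs from compound 3 in one place: methyl(phenyl)amino in place of (3-(dimethylamino)propyl)amino on a carbonyl carbon. Among the measured compounds shown here, one measured step bears on this change, since the same (3-(dimethylamino)propyl)amino left a carbonyl carbon there: a 100-fold higher number from compound 1 to compound 2 (2.01 log units; beyond the scatter). The step of a 2.6-fold lower number from compound 1 to compound 3 (0.41 log units; beyond the scatter) concerns another place and is not relevant. A large rise in number is therefore expected. Compound 4 is expected to give 3000 nM in this assay, within 400 nM to 20000 nM. The expected step is an 81-fold higher number from compound 3 to compound 4 (1.91 log units; beyond the scatter).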

Compound 4, half-maximal effective concentration: 6400 nM
Compound 4: middle estimate off by 2.1-fold (0.33 log units), on the low side; measured number inside the range.
By their numbers in this assay, from the lowest: compound 3; then compound 1; then compounds 4 and 2 (each within the scatter of the next).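

In this assay, the large rise seen earlier on the ketone compounds returns with the hydroxy group in place, a 170-fold higher number from compound 3 to compound 4 (2.24 log units; beyond the scatter), against a 100-fold higher number from compound 1 to compound 2 (2.01 log units; beyond the scatter). The loss of (3-(dimethylamino)propyl)amino on this carbonyl carbon is therefore costly in both settings, and also when the entering group holds an aromatic ring rather than a nitrile. Nothing available explains this rise. Both entering groups put a methyl on the amide nitrogen and lack the dimethylamino group, so the two changes remain unseparated. Phenylamino, or a dimethylaminopropyl chain on a methylated amide nitrogen, would separate them.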